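Shortening the aryl tail in a cytotoxicity series

A few compounds are considered here, and "the series" means these few. Any claim that something is new, unique, unknown or untested is made for them only; others in the source may bear on it.

Measured compounds:
Compound 1, `O=C(CCCCCCCc1ccccc1)N[C@H]1CCOC1=O`: > 100000 nM
Compound 2, `O=C(CCCCCCCCCCCc1ccccc1)CC(=O)N[C@H]1CCOC1=O`: 33000 nM
Compound 3, `O=C(CCCCCCCCCCc1ccccc1)CC(=O)N[C@H]1CCOC1=O`: 23000 nM

Three compounds were tested in a functional assay on NCI-H630 cells (Homo sapiens) for cytotoxicity, read by sulforhodamine B assay, with a stated time of 5 days; on this read-out higher numbers stand for weaker inhibition and lower numbers for stronger inhibition. Compound 2 `O=C(CCCCCCCCCCCc1ccccc1)CC(=O)N[C@H]1CCOC1=O` gives 33000 nM and compound 3 `O=C(CCCCCCCCCCc1ccccc1)CC(=O)N[C@H]1CCOC1=O` gives 23000 nM. The step between them, a 1.4-fold lower number from compound 2 to compound 3 (0.16 log units; within the scatter), is the change (phenyl in place of benzyl on a saturated chain carbon, ten or more bonds along the chain from a carbonyl carbon). For compound 1 `O=C(CCCCCCCc1ccccc1)N[C@H]1CCOC1=O` this assay gives only a limit, > 100000 nM, as shown by the limit of > 100000 nM in this assay, at which 1 of the 3 values shown sits. How the core of compound 1 differs from the core of compound 2 is not broken down here.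

Compound 4 `O=C(CCCCCCc1ccccc1)N[C@H]1CCOC1=O` is not yet measured. It differs from compound 1 by phenyl in place of benzyl on a saturated chain carbon, six bonds along the chain from a carbonyl carbon, the same kind of change as from compound 2 to compound 3, though at a different place along the chain. The measured step was within the scatter, so compound 4 is expected to stay near the limit of compound 1, with an estimated step of a number no higher from compound 1 to compound 4 (the limit leaves the size open). Compound 4 is estimated at 100000 nM, between 50000 nM and 300000 nM.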

Compound 4, half-maximal inhibitory concentration: > 100000 nM
Compound 4 ended at the assay's limit; the forecaster's own chance of this, stated with the estimate: 70%; the middle value sits exactly at the limit.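

In this assay no step can be read from compound 1 to compound 4, because both compounds stand at a limit rather than at a number: the limit of > 100000 nM in this assay, at which 2 of the 4 values shown sit.

The compounds shown leave open how far compound 1 and compound 4 actually lie from each other, and whether phenyl in place of benzyl matters at this place on the chain.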